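A few compounds are considered here, and "the series" means these few. Any claim that something is new, unique, unknown or untested is made for them only; others in the source may bear on it.

Working notes on the sulfonylurea series. The shared core is seen in compound 3 `CCCCCCCCCCCCCCS(=O)(=O)NC(=O)Nc1c(C(C)C)cccc1C(C)C`, which in an assay on microsomes from liver for inhibition of sterol O-acyltransferase 1 (Rattus norvegicus) (on this read-out higher numbers stand for weaker inhibition and lower numbers for stronger inhibition), gives 940 nM, the lowest number of the three measured, though compound 1 `CCCCCCCCC(C)S(=O)(=O)NC(=O)Nc1c(C(C)C)cccc1C(C)C` stands within the scatter of it with 1300 nM. Compound 2 `CCCCCCCCCCS(=O)(=O)NC(=O)Nc1c(C(C)C)cccc1C(C)C` gives 13600 nM, and the lengthening of its chain produced a 14-fold lower number from compound 2 to compound 3 (1.16 log units; beyond the scatter).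

Compound 4 `CCCCCCCCCCCCCC(C)S(=O)(=O)NC(=O)Nc1c(C(C)C)cccc1C(C)C` differs from compound 3 by methyl in place of hydrogen on a saturated chain carbon bound to a saturated chain carbon and a sulfonyl sulfur. Among the measured compounds shown here, no measured step covers this same change. The only listed step concerns the far end of the chain and does not bear on it. What can be set beside it is the pair compound 1 and compound 2: the branched compound 1 shows the lower number and the unbranched compound 2 the higher, but those two differ in more than one place, so their gap is only suggestive.

On that basis a moderate lowering is expected for compound 4, a 2.1-fold lower number from compound 3 to compound 4 (0.32 log units; beyond the scatter), with the chain already at its long form. The estimate for compound 4 is 450 nM, expected within 120 nM to 1600 nM.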

Compound 4, half-maximal inhibitory concentration: 830 nM
Compound 4: middle estimate off by 1.8-fold (0.27 log units), on the low side; measured number inside the range.
By their numbers in this assay, from the lowest: compounds 4, 3 and 1 (each within the scatter of the next); then compound 2.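

In this assay, methyl in place of hydrogen on a saturated chain carbon bound to a saturated chain carbon and a sulfonyl sulfur gives a 1.1-fold lower number from compound 3 to compound 4 (0.05 log units; within the scatter) and so leaves no readable effect on the long chain. With that methyl present, pentyl in place of hydrogen on a saturated chain carbon, nine bonds along the chain from a sulfonyl sulfur, gives only a 1.6-fold lower number from compound 1 to compound 4 (0.19 log units; within the scatter), while the butyl step on the unbranched chain gave a 14-fold lower number from compound 2 to compound 3 (1.16 log units; beyond the scatter), so among these compounds chain extension gives a step beyond the scatter only without the methyl. Nothing at hand accounts for either result.

As far as these compounds go, whether ethyl or hydroxyl on this same carbon would move the number remains open. So does the effect of a longer chain on the methyl-bearing series.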